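Aryl Sulfonamides on a Piperidinyl-Piperidine Core

This account rests on a few compounds, and the source may have more. Where it says the series, first, only, none or still open, it means among the compounds named here.

Measured so far:
compound 1, `CC1CCN(C2CCN(S(=O)(=O)c3ccc(C(C)(C)C)cc3)CC2)CC1`: > 5000 nM
compound 2, `Cc1noc(C)c1S(=O)(=O)N1CCC(N2CCC(C)CC2)CC1`: > 5000 nM
compound 3, `Cc1ccc(-c2cccc(S(=O)(=O)N3CCC(N4CCC(C)CC4)CC3)c2)cc1`: 11 nM

Three compounds share a core in which a sulfonyl group carries a varying substituent. In a functional assay on DLD-1 cells (Homo sapiens) for antiproliferative activity, read by CellTiter-Glo, with a stated time of 72 h (on this read-out higher numbers stand for weaker inhibition and lower numbers for stronger inhibition), compound 1 gives > 5000 nM, and this is a limit of the assay rather than a number. Compound 2 likewise gives only a limit, > 5000 nM, in this assay. Compound 3, in which a biaryl group sits on the sulfonyl, gives 11 nM in this assay, a measured number. Within the data shown here, compound 1 therefore stands at the limit of > 5000 nM in this assay, at which 2 of the 3 values shown sit, so its own value is only bounded from below, and no step to another measured compound is available from it.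

Compound 4, `COc1ccccc1-c1ccc(S(=O)(=O)N2CCC(N3CCC(C)CC3)CC2)cc1`, has not yet been measured. It differs from compound 1 in one place: 2-methoxyphenyl in place of tert-butyl on an aromatic carbon. Among the measured compounds shown here, the change brings a biaryl arrangement of the kind seen in compound 3, whose value of 11 nM is the only measured number among the three. Compound 4 is therefore expected to be a strong inhibitor in this assay, with an estimated step of an at least 160-fold lower number from compound 1 to compound 4 (2.22 log units; beyond the scatter) well beyond the scatter. For compound 4 the expected value is 30 nM, within a range of 5 nM to 300 nM.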

Compound 4, half-maximal inhibitory concentration: 26 nM
Estimate against measurement, compound 4: 1.2-fold (0.06 log units) above; low and high end bracket the measured number.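

Among these compounds, exchanging tert-butyl for 2-methoxyphenyl on an aromatic carbon, para to a large group, gives in this assay an at least 190-fold lower number from compound 1 to compound 4 (2.28 log units; beyond the scatter), the only step here between measured compounds that differ in one place. It shows that this single position, with the rest of the shared core unchanged, separates a compound held at a limit of the assay from one with a measured number, and that 2-methoxyphenyl is accepted there. Compound 1 stands at a limit and not at a number, so the size of the step is a bound only: the limit of > 5000 nM in this assay, at which 2 of the 4 values shown sit.

The compounds shown do not separate the part played by the added aromatic ring from that of its methoxy group, and a plain phenyl or a 2-hydroxyphenyl in the same place would be needed to tell the two apart. From the compounds shown here alone, it also remains open how this position would respond to an amine or a carboxylic acid on the outer ring, or to a saturated ring such as cyclohexyl in place of the aromatic one.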